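Cytotoxicity notes on a hydroxyphenyl-pyridine series

The compounds below may be only part of what the source reports. "The series", "measured", "known", "first", "only" and "open" are said of these compounds alone.

Measured so far in an ADME assay on HEK293 cells (Homo sapiens) for cytotoxicity, read by CCK-8 assay and cell counting, with a stated time of 2 days; a higher number here means a weaker inhibitor, a lower number a stronger inhibitor:
compound 1, `Oc1cccc(-c2cc(-c3ccc(Cl)cc3)nc(-c3cccs3)c2)c1`, 11800 nM
compound 2, `Oc1cccc(-c2cc(-c3ccc(Cl)cc3)nc(-c3cccnc3)c2)c1`, 39500 nM
compound 3, `Oc1ccc(-c2cc(-c3cccc(Cl)c3)nc(-c3cccs3)c2)cc1`, 2720 nM

Compound 3 gives the lowest number of the three. Compound 1 and compound 3 are built from the same atoms joined differently; the difference between the two cores is not broken down here.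

One exchange is shown once with a measurement. From compound 1 to compound 2 the change is pyridin-3-yl in place of thiophen-2-yl on an aromatic carbon, and in this assay it gave a 3.3-fold higher number from compound 1 to compound 2 (0.52 log units; beyond the scatter).

Compound 4, `Oc1ccc(-c2cc(-c3cccnc3)nc(-c3cccc(Cl)c3)c2)cc1`, is not yet measured. From compound 3 to compound 4 the change is pyridin-3-yl in place of thiophen-2-yl on an aromatic carbon. The surroundings differ: in compound 1 the site is meta to a 3-hydroxyphenyl group and meta to a 4-chlorophenyl group, in compound 3 it is meta to a 3-chlorophenyl group and meta to a 4-hydroxyphenyl group, so this is the same kind of change, not the same.

Among the compounds with values here, the step from compound 3 to compound 4 in this assay is expected to be a 3.3-fold higher number from compound 3 to compound 4 (0.52 log units; beyond the scatter), resting on the one measured instance, a 3.3-fold higher number from compound 1 to compound 2 (0.52 log units; beyond the scatter). Compound 4 is thus estimated at 9000 nM, expected between 4000 nM and 20000 nM.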

Compound 4, half-maximal inhibitory concentration: 25700 nM
Estimate against measurement, compound 4: 2.9-fold (0.46 log units) below; the measured number lies above the stated range.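

In this assay, pyridin-3-yl in place of thiophen-2-yl gave a 9.4-fold higher number from compound 3 to compound 4 (0.98 log units; beyond the scatter). The number rises on both cores, but the size of the rise does not carry over from one core to the other: the same change on two cores in this assay, a 3.3-fold higher number (0.52 log units; beyond the scatter) from compound 1 to compound 2 and a 9.4-fold higher number (0.98 log units; beyond the scatter) from compound 3 to compound 4, 2.8-fold (0.45 log units) apart, beyond the scatter of two such steps. These two pairs show that the direction held and that a step measured on one core did not give its size on the other; they do not show which feature of the cores sets the gap, nor that the direction would hold on a further core.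

The compounds shown do not separate the contribution of the 3-hydroxyphenyl and 4-chlorophenyl arrangement from that of the 3-chlorophenyl and 4-hydroxyphenyl arrangement, as the two cores differ in both groups at once. Also open, as far as these compounds go, is how this assay would read with an amine or a carboxylic acid in place of the hydroxyl group, and whether the exchange would then keep its direction.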